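This account rests on a few compounds, and the source may have more. Where it says the series, first, only, none or still open, it means among the compounds named here.

Of the compounds shown here, three have values so far in an ADME assay for permeability, using PAMPA, at pH 7.4 (a lower number here means that the compound crosses the layer more slowly, a higher number that the compound crosses the layer faster), and a fourth awaits measurement.

- compound 1 `Cc1[nH]c2ccccc2c(=O)c1Cc1ccccc1` gives 102 10^-6 cm/s
- compound 2 `Cc1[nH]c2ccc(Cl)cc2c(=O)c1Br` gives 87.7 10^-6 cm/s
- compound 3 `COc1cccc2[nH]c(C)c(Cc3ccccc3)c(=O)c12` gives 158 10^-6 cm/s

Compound 3 (158 10^-6 cm/s) lies within the usual scatter of both other compounds, so these three values cannot be ranked in this assay with any confidence.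

The next compound is compound 4 `Cc1[nH]c2cccc(Cl)c2c(=O)c1Cc1ccccc1` and it has chloro in place of methoxy on an aromatic carbon, ortho to a fused ring and meta to a fused ring (chloro in place of methoxy on an aromatic carbon). Within the data shown here, no measured step shows this exact swap. The nearest evidence is methoxy in place of hydrogen on an aromatic carbon, which gave a 1.5-fold higher number from compound 1 to compound 3 (0.19 log units; within the scatter) and stayed within the scatter. Compound 2 also carries chloro, though the rest of its structure differs, and its value (87.7 10^-6 cm/s) lies within the scatter of the others.

The expected outcome is a 1.2-fold lower number from compound 3 to compound 4 (0.08 log units; within the scatter) and thus no step beyond the scatter. The estimate for compound 4 is 130 10^-6 cm/s (expected range 70 10^-6 cm/s to 240 10^-6 cm/s).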

Compound 4, apparent permeability in the ADME assay: 251 10^-6 cm/s
Compound 4: middle estimate off by 1.9-fold (0.29 log units), on the low side; measured number outside the range, above it.
By their numbers in the ADME assay, from the lowest: compounds 2, 1, 3 and 4 (each within the scatter of the next, the first and the last beyond it).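

Among these compounds, at this position, chloro in place of hydrogen gives a 2.5-fold higher number from compound 1 to compound 4 (0.39 log units; beyond the scatter) in the ADME assay, the first step here beyond the scatter, whereas chloro in place of methoxy gives a 1.6-fold higher number from compound 3 to compound 4 (0.20 log units; within the scatter). In a physicochemical assay for solubility, read by HPLC, at pH 7.4 (on this read-out higher numbers stand for higher solubility and lower numbers for lower solubility), that same swap does separate the two compounds: an at least 10-fold lower number from compound 3 to compound 4 (1.00 log units; beyond the scatter). In the physicochemical assay compound 4 gives 2000 nM. In the physicochemical assay compound 3 gives > 20000 nM, which is a limit of that assay rather than a number, so this step is only a minimum: the limit of > 20000 nM in the physicochemical assay, at which 1 of the 2 values shown sits.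

The compounds shown leave open how a fluoro, a nitrile or an amine at this position would read in the ADME assay and the physicochemical assay. They also leave open whether any group here can combine a high number in the ADME assay with a high number in the physicochemical assay.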